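The compounds below may be only part of what the source reports. "The series", "measured", "known", "first", "only" and "open" are said of these compounds alone.

Working notes on the series. All four members share the core shown for compound 1 `Cc1c(C(=O)NCc2ccccc2)nc(-c2ccc(F)cc2)n1CC[C@@H](O)C[C@@H](O)CC(=O)O`; compound 2 `COc1ccc(CNC(=O)c2nc(-c3ccc(F)cc3)n(CC[C@@H](O)C[C@@H](O)CC(=O)O)c2C2CC2)cc1` and compound 3 `CN(C)S(=O)(=O)c1ccc(CNC(=O)c2nc(-c3ccc(F)cc3)n(CC[C@@H](O)C[C@@H](O)CC(=O)O)c2C2CC2)cc1` carry a cyclopropyl where compound 1 carries a methyl, and their benzylamides bear a group on the ring. In an assay on microsomes from liver for inhibition of 3-hydroxy-3-methylglutaryl-coenzyme A reductase (Rattus norvegicus), read by scintillation counting, with stated times of 0.5 h and 0.75 h (on this read-out higher numbers stand for weaker inhibition and lower numbers for stronger inhibition), compound 1 gives 94 nM, compound 2 gives 1.2 nM and compound 3 gives 4.9 nM. Compound 3 thus stands second of the three numbers, with compound 2 nearest and compound 1 furthest. For the measured compounds named here, the only single-point step measured so far is a 4.1-fold higher number from compound 2 to compound 3 (0.61 log units; beyond the scatter).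

Compound 4 `O=C(O)C[C@H](O)C[C@H](O)CCn1c(-c2ccc(F)cc2)nc(C(=O)NCc2ccccc2)c1C1CC1` is still unmeasured. Its change from compound 3 is hydrogen in place of dimethylsulfamoyl on an aromatic carbon; the site is an aromatic carbon of a six-membered aromatic ring of carbon only, para to a large group. Going by the values given here, the one step that bears on this site is the exchange from compound 2 to compound 3, a modest rise for a larger group in place of methoxy; no measured pair shows that carbon bare against any group. Compound 1 also carries the bare benzyl, but differs from compound 4 in methyl against cyclopropyl as well, so its value can only be set beside the others, not read as a step.

Compound 4 is expected near 3 nM, within a range of 1 nM to 10 nM. That estimate means an expected 1.6-fold lower number from compound 3 to compound 4 (0.21 log units; within the scatter), a step not expected to exceed the scatter.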

Compound 4, half-maximal inhibitory concentration: 1.4 nM
The estimate for compound 4 lay 2.1-fold (0.33 log units) above the measured number; the measured number falls inside the stated range.
By their numbers in this assay, from the lowest: compounds 2 and 4 (each within the scatter of the next); then compound 3; then compound 1.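

For the compounds shown here, the bare benzylamide gives the first reading of this ring carbon without a group. In this assay, losing dimethylsulfamoyl gives a 3.5-fold lower number from compound 3 to compound 4 (0.54 log units; beyond the scatter), whereas hydrogen in place of methoxy gives only a 1.2-fold higher number from compound 2 to compound 4 (0.07 log units; within the scatter), so among these three substituents only dimethylsulfamoyl stands apart, and methoxy cannot be told from hydrogen. Going by these compounds alone, compound 4 also gives the first single-change reading at the other site, where cyclopropyl in place of methyl on an aromatic carbon gives a 67-fold lower number from compound 1 to compound 4 (1.83 log units; beyond the scatter), a much larger step than either one at the ring carbon.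

Nothing shown here gives a reason for any of these steps. Still open, as far as these compounds go, are whether an amine, a carboxylic acid or a fluorine atom at this ring carbon would separate from hydrogen as dimethylsulfamoyl does, and whether an isopropyl or a phenyl group in place of cyclopropyl would hold the number reached with compound 4.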